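Methyl on the anilino ring of a pyrimidine series

The source may hold more compounds than are shown below. What is called first, only, known or untested is meant among the compounds shown, and "the series" means these compounds.

Measured so far:
compound 1, `CCN1CCN(c2ccc(Nc3ncc(Cl)c(Nc4ccccc4C)n3)nc2)CC1` — > 100000 nM in a functional assay on MCF7 cells (Homo sapiens) for inhibition, read by CCK-8 assay, with a stated time of 48 h; a higher number here means a weaker inhibitor of growth, a lower number a stronger inhibitor of growth
compound 2, `CN1CCN(c2ccc(Nc3ncc(Cl)c(Nc4ccccc4)n3)nc2)CC1` — 51800 nM

For the measured compounds named here, compound 2 gives 51800 nM in this assay, the only number among the values shown. Compound 1 stands at > 100000 nM, which is a limit of this assay and not a number, the limit noted as the limit of > 100000 nM in this assay, at which 1 of the 2 values shown sits. Going by the values given here, no step between measured compounds is given here.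

Compound 3, `Cc1cccc(Nc2nc(Nc3ccc(N4CCN(C)CC4)cn3)ncc2Cl)c1`, is not yet measured. It differs from compound 2 by methyl in place of hydrogen on an aromatic carbon. Among the compounds with values here, since no measured step shows what a methyl in place of hydrogen on an aromatic carbon does, no change beyond the usual scatter of this assay is expected in either direction. Compound 3 is therefore estimated to lie near compound 2, at 45000 nM, with a range from 15000 nM to 100000 nM. The step from compound 2 to compound 3 that this estimate means, a 1.2-fold lower number from compound 2 to compound 3 (0.06 log units; within the scatter), is expected to stay within the scatter.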

Compound 3, concentration for 50% growth inhibition: 7160 nM
Compound 3: middle estimate off by 6.3-fold (0.80 log units), on the high side; the measured number lies below the stated range.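

In this assay, for the compounds shown here, a methyl in place of hydrogen on an aromatic carbon, meta to a large group, is the first change that can be read as a single step, and it is not a silent one: phenyl to 3-methylphenyl gives a 7.2-fold lower number from compound 2 to compound 3 (0.86 log units; beyond the scatter). This place on the anilino ring therefore accepts a methyl, and the number moves lower, though only modestly and with growth inhibition still weak in absolute terms. The step rests on this single pair, and nothing measured here accounts for it.

The compounds shown leave open whether an ethyl, a methoxy group, a chlorine atom or an amine at this same place would move the number further. Compound 1, whose > 100000 nM is a limit of the assay and not a number, differs from the others in more than one place, so it cannot show what a methyl does elsewhere on that ring.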